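One amine ring for another on the shared chain

The compounds below may be only part of what the source reports. "The series", "measured", "known", "first", "only" and "open" are said of these compounds alone.

In a functional assay on the whole organism with Mus musculus as the target, in the maximal electroshock model, at a dose of 50 mg/kg by the oral route (a higher number here means more inhibition at the dose given (going by the name of the read-out), a lower number less inhibition), compound 2 `OC1CCN(CCCCOc2ccccc2/C=C/c2ccccc2)CC1` gives 0%. That is level with compound 1 `CN(C)CCCCOc1ccccc1/C=C/c1ccc(Cl)cc1`, which gives 0%, and together these two stand lowest of the three numbers. Compound 3 `COc1cccc(OCCCCN2CCN(C)CC2)c1/C=C/c1ccccc1` gives 42.9%, a gap from compound 2 that lies beyond the usual scatter. Compound 4 `CC1CCCN(CCCCOc2ccccc2/C=C/c2ccccc2)C1` is not yet measured; it differs from compound 2 in one place: 3-methylpiperidin-1-yl in place of 4-hydroxypiperidin-1-yl on a saturated chain carbon, four bonds along the chain from an oxygen on an aromatic ring. Compound 1 and compound 2 carry different amines yet both show no inhibition, so there is little ground to expect a change of the amine ring alone to lift the number much, while compound 3, which differs in more than the amine, gives the higher value. For compound 4 the expected value is 10%, between 0% and 40%. The step this estimate implies is a number 10 percentage points higher from compound 2 to compound 4 (within the scatter), expected to be small or none beyond the scatter.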

Compound 4, a percentage reported as inhibition, in the whole organism at one dose (the size of the read-out at that dose, not a potency): 12.5%
For compound 4 the middle estimate is 2.5 percentage points below the measured one; measured number inside the range.
By their numbers in this assay, from the lowest: compounds 1 and 2 (each within the scatter of the next); then compound 4; then compound 3.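

In this assay, exchanging the amine ring at this place on the chain gives a number 12.5 percentage points higher from compound 2 to compound 4 (beyond the scatter), so a change of the amine ring alone can move the number, though the step is modest. The exchange also swaps a ring with one hydrogen-bond donor for a ring with none. Nothing here explains the step.

Still open, going by these compounds, is whether the step follows the loss of the hydroxy group or the arrival of the methyl group, since both change together. A plain piperidin-1-yl ring on the same chain would help separate the two.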